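Chain length at the ring amine nitrogen

The source may hold more compounds than are shown below. What is called first, only, known or untested is meant among the compounds shown, and "the series" means these compounds.

The series holds a shared core carrying a chain on the ring amine nitrogen. In a functional assay on cells (T-cell line, Homo sapiens) for inhibition (on this read-out higher numbers stand for weaker inhibition and lower numbers for stronger inhibition), compound 1 `CCN1CCC(COC(c2ccccc2)c2ccccc2)CC1` gives only a limit, > 20000 nM, and not a number (the limit of > 20000 nM in this assay, at which 1 of the 3 values shown sits). Compound 2 `CCCN1CCC(COC(c2ccccc2)c2ccccc2)CC1` gives 17800 nM in this assay, and compound 3 `CCCCCCCCN1CCC(COC(c2ccccc2)c2ccccc2)CC1` gives 700 nM. The change methyl in place of hydrogen on a saturated chain carbon, two bonds along the chain from an amine nitrogen in a ring made an at least 1.1-fold lower number from compound 1 to compound 2 (0.05 log units; that floor lies within the scatter). The change hexyl in place of hydrogen on a saturated chain carbon, two bonds along the chain from an amine nitrogen in a ring made an at least 28-fold lower number from compound 1 to compound 3 (1.45 log units; beyond the scatter), and a 25-fold lower number from compound 2 to compound 3 (1.41 log units; beyond the scatter). Compound 4 `CCCCCCCCCN1CCC(COC(c2ccccc2)c2ccccc2)CC1` is not yet measured; its difference from compound 3 is methyl in place of hydrogen on a saturated chain carbon, eight bonds along the chain from an amine nitrogen in a ring, the same kind of change as from compound 1 to compound 2, but placed eight bonds along the chain rather than two. For compound 4 in this assay a step of a 1.4-fold lower number from compound 3 to compound 4 (0.15 log units; within the scatter) is expected, resting on compound 1 to compound 2 an at least 1.1-fold lower number from compound 1 to compound 2 (0.05 log units; that floor lies within the scatter) being small while compound 2 to compound 3 a 25-fold lower number from compound 2 to compound 3 (1.41 log units; beyond the scatter) was large. Compound 4 is therefore estimated at 500 nM, between 150 nM and 1500 nM.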

Compound 4, half-maximal inhibitory concentration: 700 nM
Beside the measured number, compound 4's estimate is 1.4-fold (0.15 log units) below it; low and high end bracket the measured number.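

In this assay, methyl in place of hydrogen, eight bonds along the chain from an amine nitrogen in a ring, gave no change at the digits printed from compound 3 to compound 4 (within the scatter), and whether this matches the same change placed two bonds along the chain cannot be told: the same change on two cores in this assay, an at least 1.1-fold lower number (0.05 log units; that floor lies within the scatter) from compound 1 to compound 2 and no change at the digits printed (within the scatter) from compound 3 to compound 4; the limit leaves it open whether they differ

Hexyl in place of hydrogen gave a 25-fold lower number from compound 2 to compound 4 (1.41 log units; beyond the scatter) and heptyl gave an at least 28-fold lower number from compound 1 to compound 4 (1.45 log units; beyond the scatter), so a large step recurs on these cores, though equal size on both is not shown: the same change on two cores in this assay, an at least 28-fold lower number (1.45 log units; beyond the scatter) from compound 1 to compound 3 and a 25-fold lower number (1.41 log units; beyond the scatter) from compound 2 to compound 4; the limit leaves it open whether they differ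

Compound 1 gives a limit and not a number: the limit of > 20000 nM in this assay, at which 1 of the 4 values shown sits.

Open, going by these compounds, is where the large step falls among chain lengths between those of compound 2 and compound 3. Also open, on these data alone, is how a longer chain, or a chain ending in a carboxylic acid or an amine, would read out.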